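The compounds below may be only part of what the source reports. "The series", "measured", "known", "first", "only" and "open" are said of these compounds alone.

Working notes on the series. In a functional assay on THP-1 cells (Homo sapiens) for inhibition, read by sulforhodamine B assay, with a stated time of 48 h, tested at 50 uM (on this read-out higher numbers stand for more inhibition of growth at the one concentration tested and lower numbers for less inhibition of growth), compound 1 `COc1ccc(/C=C/C(=O)/C=C/c2ccc(OCc3cn(CCCCCOc4cc(=O)oc5ccccc45)nn3)c(OC)c2)cc1` gives 39%, while compound 2 `COc1ccc(/C=C/C(=O)/C=C/c2ccc(OCc3cn(CCOc4cc(=O)oc5ccccc45)nn3)c(OC)c2)cc1` gives 78%; compound 1 thus stands lowest of the two numbers shown, and the distance to compound 2 lies beyond the scatter. Compound 3 `COc1ccc(/C=C/C(=O)/C=C/c2ccc(OCc3cn(CCCCCOc4cc(=O)oc5ccccc45)nn3)c(OC)c2)cc1OC` differs from compound 1 by methoxy in place of hydrogen on an aromatic carbon. Among the compounds with values here, no measured pair shows this change on its own, so nothing supports a step beyond the scatter. The step of a number 6 percentage points higher from compound 1 to compound 3 (within the scatter) is therefore expected to be small, if anything toward slightly higher inhibition. Compound 3 is estimated at about 45%, in the range 25% to 65%.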

Compound 3, percent growth inhibition at one concentration: 47%
Compound 3: middle estimate off by 2 percentage points, on the low side, and the stated range covers the measured number.
By their numbers in this assay, from the lowest: compounds 1 and 3 (each within the scatter of the next); then compound 2.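

In this assay, methoxy in place of hydrogen on this aromatic carbon, turning 4-methoxyphenyl into 3,4-dimethoxyphenyl, reads as a number 8 percentage points higher from compound 1 to compound 3 (within the scatter). This position of compound 1 therefore takes a second methoxy without a change that can be told from the scatter. Nothing available accounts for this result.

Going by these compounds, whether a hydroxyl, an amine or an ethoxy at this carbon would move the number stays open. So does whether the same methoxy would act alike on compound 2.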